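The compounds below may be only part of what the source reports. "The series", "measured", "known", "first", "only" and "open" are said of these compounds alone.

Measured so far in an ADME assay on cells for inhibition of cytochrome P450 11B1, mitochondrial (Homo sapiens), read by HTRF; on this read-out lower numbers stand for stronger inhibition and higher numbers for weaker inhibition:

- Compound 1 `CC(=O)N[C@@H]1CCCc2c1cncc2N1C(=O)c2ccc(Cl)cc2[C@@H]1C1CC1`: > 30000 nM. For compound 1 this is a limit of the assay, not a number, as stated by the limit of > 30000 nM in this assay, at which 1 of the 3 values shown sits.
- Compound 2 `CC[C@@H]1c2cc(Cl)ccc2C(=O)N1c1cncc2c1CCC[C@H]2NC(C)=O`: 334 nM.
- Compound 3 `CCS(=O)(=O)N[C@@H]1CCCc2c1cncc2N1Cc2cc(Cl)ccc2C1=O`: 1790 nM.

For the measured compounds named here, only two compounds give an actual number in this assay, and compound 3 holds the higher of them, meaning the weaker inhibition. The nearest number, that of compound 2, lies beyond the usual scatter below it, so the two are genuinely apart. Compound 1 gives no number at all, only a limit.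

The next compound, compound 4 `CC(=O)N[C@@H]1CCCc2c1cncc2N1Cc2cc(Cl)ccc2C1=O`, is compound 3 with one change: acetyl in place of ethylsulfonyl on an amine nitrogen. Going by the values given here, no pair of measured compounds shows this exact exchange, so there is no measured step to lean on. Compounds 1 and 2 both carry the acetamido that enters here, yet differ from each other in the shared core, and they span from a limit to a low number, which gives no clean guide. The expectation for the step from compound 3 to compound 4 is therefore a change of modest size, a 1.5-fold lower number from compound 3 to compound 4 (0.17 log units; within the scatter), with direction uncertain and possibly none beyond the scatter. Compound 4 is estimated at 1200 nM in this assay, within a range from 300 nM to 5000 nM.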

Compound 4, half-maximal inhibitory concentration: 2330 nM
Estimate against measurement, compound 4: 1.9-fold (0.29 log units) below; low and high end bracket the measured number.
By their numbers in this assay, from the lowest: compound 2; then compounds 3 and 4 (each within the scatter of the next). At a limit, above all of these: compound 1.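

In this assay, the exchange on the amine nitrogen gives a 1.3-fold higher number from compound 3 to compound 4 (0.11 log units; within the scatter), so although acetyl is the smaller group, ethylsulfonyl and acetyl cannot be told apart here. With the acetamido held in place, the saturated ring carbon turns out to matter much more: removing ethyl from that carbon gives a 7.0-fold higher number from compound 2 to compound 4 (0.84 log units; beyond the scatter), so in this pair the ethyl goes with the stronger inhibition. Removing cyclopropyl from a saturated ring carbon points the opposite way, with an at least 12-fold lower number from compound 1 to compound 4 (1.10 log units; beyond the scatter), but compound 1 stands at a limit, so this step gives only a bound and not an exact size: the limit of > 30000 nM in this assay, at which 1 of the 4 values shown sits.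

As far as these compounds go, it remains open how a methyl or a propyl on that saturated ring carbon would read, and so where the line falls between a chain that goes with stronger inhibition and a ring that goes with much weaker inhibition. From the compounds shown here alone, it is also open whether a free amine or a urea on the amine nitrogen would stay level with the acetyl and ethylsulfonyl compounds.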